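Hydroxamate chain length across two aminopyrazolopyrimidine cores

A few compounds are considered here, and "the series" means these few. Any claim that something is new, unique, unknown or untested is made for them only; others in the source may bear on it.

Measured so far in a functional assay on Bel-7402 cells (Homo sapiens) for inhibition, read by MTT assay, with a stated time of 72 h; on this read-out lower numbers stand for stronger inhibition and higher numbers for weaker inhibition:
compound 1, `Nc1ncnc2c1c(-c1cnc3[nH]ccc3c1)nn2CCCCCCCCCC(=O)NO`, gives 42100 nM
compound 2, `Nc1ncnc2c1c(-c1cnc3[nH]ccc3c1)nn2CCCCCCC(=O)NO`, gives 30800 nM
compound 3, `Nc1nc2cc(-c3nn(CCCCCC(=O)NO)c4ncnc(N)c34)ccc2o1`, gives 2030 nM

Compounds 1 and 2 share one core and differ only in the length of the chain carrying the hydroxamic acid. The change, (3-(hydroxycarbamoyl)propyl in place of hydroxycarbamoyl on a saturated chain carbon, six bonds along the chain from an aromatic nitrogen), is the only difference between them, and the step it made in this assay is a 1.4-fold higher number from compound 2 to compound 1 (0.14 log units; within the scatter). Compound 3 carries a different core, and the difference between the two cores is not broken down here. What the values show is that compound 3 gives a clearly lower number than either compound 1 or compound 2, beyond the usual scatter in both cases.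

Compound 4, `Nc1nc2cc(-c3nn(CCCCCCCCC(=O)NO)c4ncnc(N)c34)ccc2o1`, has not been measured in this assay. It stands to compound 3 as compound 1 stands to compound 2: the change is 3-(hydroxycarbamoyl)propyl in place of hydroxycarbamoyl on a saturated chain carbon, five bonds along the chain from an aromatic nitrogen. The two places are not identical, since in compound 2 the change sits six bonds along the chain from an aromatic nitrogen and in compound 3 five bonds along, so this is the same kind of change rather than the same change.

The step is expected to be small: on the core of compound 2 the same kind of lengthening made a 1.4-fold higher number from compound 2 to compound 1 (0.14 log units; within the scatter), a step within the scatter, and nothing in the data points to a different outcome on the core of compound 3. The step from compound 3 to compound 4 is therefore estimated at a 1.3-fold higher number from compound 3 to compound 4 (0.12 log units; within the scatter). For compound 4 in this assay the estimate is 2700 nM, with a plausible range from 1200 nM to 7000 nM, resting on the value of compound 3, 2030 nM, and the step measured between compounds 2 and 1.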

Compound 4, half-maximal inhibitory concentration: > 100000 nM
Compound 4: no number, only a limit (the forecaster's own chance of this, stated with the estimate: 3%); middle value at least 37-fold (1.56 log units) away from the limit.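

In this assay compound 4 gives > 100000 nM, which is a limit of the assay and not a number: the limit of > 100000 nM in this assay, at which 1 of the 4 values shown sits.

Carried to the second core, the change from hydroxycarbamoyl to 3-(hydroxycarbamoyl)propyl gives an at least 49-fold higher number from compound 3 to compound 4 (1.69 log units; beyond the scatter), so the full size of this step stays unknown, and the data do not say what in the two cores sets the outcomes apart. The size of the step therefore does not carry from one core to the other in this pair of pairs, and a single pair on one core proves a poor guide to the same lengthening on another: the same change on two cores in this assay, a 1.4-fold higher number (0.14 log units; within the scatter) from compound 2 to compound 1 and an at least 49-fold higher number (1.69 log units; beyond the scatter) from compound 3 to compound 4, at least 36-fold (1.55 log units) apart, beyond the scatter of two such steps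

Open, from the compounds shown here alone, is how the number moves with chains of intermediate length on the core of compound 3, and whether the rise comes gradually or at one particular length. Also open, going by these compounds, is whether a still longer chain on the core of compound 1 would show a similar rise, and how a carboxylic acid in place of the hydroxamic acid would behave on either core.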